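This account rests on a few compounds, and the source may have more. Where it says the series, first, only, none or still open, it means among the compounds named here.

Compound 2 `O=S(=O)(NCCCNCc1ccc(Cl)c(Cl)c1)c1cc(C(F)(F)F)cc(C(F)(F)F)c1` and compound 1 `O=S(=O)(NCCCNCc1ccccc1Cl)c1cc(C(F)(F)F)cc(C(F)(F)F)c1` share the same core and differ only in the benzyl group attached to the amine nitrogen. Going by the values given here, in a functional assay on ASPC1 cells (Homo sapiens) for inhibition, read by MTT assay, with a stated time of 72 h (a higher number here means a weaker inhibitor of growth, a lower number a stronger inhibitor of growth), compound 1 gives 13000 nM, while compound 2 gives 2800 nM, which is the lowest of the two numbers measured so far; the change in a 4.6-fold lower number from compound 1 to compound 2 (0.67 log units; beyond the scatter) is the only step on record. Compound 3 `CN(CCCNS(=O)(=O)c1cc(C(F)(F)F)cc(C(F)(F)F)c1)Cc1ccccc1` takes this further in a different direction: benzyl(methyl)amino in place of (3,4-dichlorobenzyl)amino on a saturated chain carbon, three bonds along the chain from a sulfonamide nitrogen. Among the compounds with values here, the one measured step bears on it only indirectly, since it shows that moving chlorine atoms on this ring shifted the number in this assay by a modest but clear margin; here both chlorines leave and the amine hydrogen is replaced by a methyl, with nothing measured for either change. A step back toward higher numbers is therefore expected, roughly a 3.6-fold higher number from compound 2 to compound 3 (0.55 log units; beyond the scatter), and compound 3 is estimated at 10000 nM, within a range from 3500 nM to 30000 nM.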

Compound 3, concentration for 50% growth inhibition: 51000 nM
Beside the measured number, compound 3's estimate is 5.1-fold (0.71 log units) below it, and the stated range ends below it.
By their numbers in this assay, from the lowest: compound 2; then compound 1; then compound 3.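

In this assay the change to benzyl(methyl)amino gives an 18-fold higher number from compound 2 to compound 3 (1.26 log units; beyond the scatter) and also a 3.9-fold higher number from compound 1 to compound 3 (0.59 log units; beyond the scatter) in the same direction. The step from compound 2 is large, whereas the earlier step between the two chlorinated compounds was modest, so the group on this amine can shift growth inhibition much further than moving chlorine on the ring does. No measurement here explains this rise.

The change removes the chlorine and puts a methyl on the amine nitrogen at once, so the compounds shown cannot separate the two contributions. A plain benzylamino group, with no chlorine and no methyl, or a 3,4-dichlorobenzyl(methyl)amino group, would tell them apart.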